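The source may hold more compounds than are shown below. What is called first, only, known or untested is meant among the compounds shown, and "the series" means these compounds.

Three compounds sharing one core, and differing only in the group carried on the carbonyl carbon of the amide, have been tested in a functional assay on cells for positive allosteric modulation of metabotropic glutamate receptor 5 (Rattus norvegicus), read by calcium flux; on this read-out lower numbers stand for an effect already at smaller amounts and higher numbers for an effect only at larger amounts of compound. Compound 1 `O=C(Nc1cc(-c2ccccc2)nn1-c1ccccc1)c1cccc(C(F)(F)F)c1` gives 228 nM, compound 2 `COc1cc(OC)cc(C(=O)Nc2cc(-c3ccccc3)nn2-c2ccccc2)c1` gives 2040 nM, and compound 3 `Cc1ccc(C(=O)Nc2cc(-c3ccccc3)nn2-c2ccccc2)cn1` gives 280 nM. Compound 3 thus stands close to compound 1, the two within the scatter of each other, and well apart from compound 2, that gap lying beyond the scatter. The steps seen so far were an 8.9-fold higher number from compound 1 to compound 2 (0.95 log units; beyond the scatter), a 1.2-fold higher number from compound 1 to compound 3 (0.09 log units; within the scatter) and a 7.3-fold lower number from compound 2 to compound 3 (0.86 log units; beyond the scatter), so exchanging one aromatic group for another has moved the number at most modestly. Compound 4 `O=C(CC1CCCC1)Nc1cc(-c2ccccc2)nn1-c1ccccc1` carries the change (cyclopentylmethyl in place of 6-methylpyridin-3-yl on a carbonyl carbon). Among the compounds with values here, no measured step exchanges an aromatic group for a non-aromatic ring, so the steps seen bear on it only loosely. The expected step is a 2.5-fold higher number from compound 3 to compound 4 (0.40 log units; beyond the scatter), a modest rise with wide uncertainty. For compound 4 the estimate is 700 nM, with a range from 230 nM to 2100 nM.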

Compound 4, half-maximal effective concentration: 350 nM
For compound 4 the middle estimate is 2.0-fold (0.30 log units) above the measured one, within the range that was stated.
By their numbers in this assay, from the lowest: compounds 1, 3 and 4 (each within the scatter of the next); then compound 2.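

In this assay, the group on the carbonyl carbon need not be aromatic among these compounds: cyclopentylmethyl, a non-aromatic carbon ring, gives a 1.3-fold higher number from compound 3 to compound 4 (0.10 log units; within the scatter) and a 1.5-fold higher number from compound 1 to compound 4 (0.19 log units; within the scatter) and so cannot be told apart from either aromatic group. One aromatic example stands apart, since cyclopentylmethyl in place of 3,5-dimethoxyphenyl gives a 5.8-fold lower number from compound 2 to compound 4 (0.77 log units; beyond the scatter) and so being aromatic or not does not by itself sort these groups. No independent measurement is available to explain these results.

With a single non-aromatic group shown, it remains open whether this result extends to a cyclopentyl ring joined directly to the carbonyl carbon, a cyclohexylmethyl group or a longer open chain. On these data alone, it is equally open how an amine or a carboxylic acid on such a group would fare.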